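Swapping the ester of compound 2 for phenyl

The compounds below may be only part of what the source reports. "The series", "measured", "known", "first", "only" and "open" are said of these compounds alone.

Compound 1 `Cc1ccc(NC(=O)CCc2cccc3c2B(O)OC3)cc1`: 1100 nM
Compound 2 `CCOC(=O)c1ccc(NC(=O)CCc2cccc3c2B(O)OC3)cc1`: > 100000 nM, a limit

In a functional assay on MDA-MB-231 cells (Homo sapiens) for antiproliferative activity, read by MTT assay, with a stated time of 72 h (on this read-out lower numbers stand for stronger inhibition and higher numbers for weaker inhibition), compound 1 gives 1100 nM. Compound 2 reads > 100000 nM, which is a limit and not a number. Its standing is therefore given only by the limit of > 100000 nM in this assay, at which 1 of the 2 values shown sits. For the measured compounds named here, the one measured step is an at least 90-fold higher number from compound 1 to compound 2 (1.95 log units; beyond the scatter), with ethoxycarbonyl in place of methyl on an aromatic carbon.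

Compound 3 `O=C(CCc1cccc2c1B(O)OC2)Nc1ccc(-c2ccccc2)cc1` has not yet been measured. It carries phenyl in place of ethoxycarbonyl on an aromatic carbon, para to a large group: phenyl in place of ethoxycarbonyl on an aromatic carbon. Compound 3 thus loses the group that came with an at least 90-fold higher number from compound 1 to compound 2 (1.95 log units; beyond the scatter), so a large move towards a lower number is expected. Going by the values given here, that single step is the only guide, and no measured compound carries phenyl, so the size remains uncertain and a reading near the limit cannot be ruled out. The expected change is an at least 20-fold lower number from compound 2 to compound 3 (1.30 log units; beyond the scatter). For compound 3 the estimated value is 5000 nM, with an expected range from 700 nM to 40000 nM.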

Compound 3, half-maximal inhibitory concentration: 8800 nM
The estimate for compound 3 lay 1.8-fold (0.25 log units) below the measured number, and the stated range covers the measured number.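

In this assay, phenyl on this aromatic carbon, para to a large group, brings the reading back from the limit, with an at least 11-fold lower number from compound 2 to compound 3 (1.05 log units; beyond the scatter), even though phenyl has 6 heavy atoms against the 5 of the ethoxycarbonyl that leaves. Heavy-atom count alone therefore does not order compound 2 and compound 3, and the full loss seen with ethoxycarbonyl is not shared by every large group at this place. Phenyl still does not match methyl, with an 8.0-fold higher number from compound 1 to compound 3 (0.90 log units; beyond the scatter), so compound 1 keeps the lowest number of the three, and phenyl recovers only part of what ethoxycarbonyl lost.

As far as these compounds go, the true size of the step between compound 2 and compound 3 stays open because compound 2 has a limit and not a number: the limit of > 100000 nM in this assay, at which 1 of the 3 values shown sits. From the compounds shown here alone, three groups also cannot show what sets the order among them, and it remains open where an amine, a carboxylic acid or a longer alkyl chain on this carbon would fall relative to methyl and phenyl.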